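A bromophenyl swap on compound 2

The source may report more compounds than this note shows. Statements on the series, on what has been measured and on what is new or still open speak of the compounds shown alone.

Compound 1 `COc1ccc(NC(=O)CN2CCN(c3nnc(Cc4ccncc4)c4ccccc34)CC2)cc1OC` gives 26500 nM
Compound 2 `O=C(CN1CCN(c2nnc(Cc3ccccc3)c3ccccc23)CC1)Nc1c(F)cccc1F` gives 84500 nM
Compound 3 `O=C(CN1CCN(c2nnc(Cc3ccncc3)c3ccccc23)CC1)Nc1cccc(F)c1` gives 4600 nM

All three values come from a functional assay on A549 cells (Homo sapiens) for cytotoxicity, read by MTT assay, with a stated time of 72 h; on this read-out lower numbers stand for stronger inhibition and higher numbers for weaker inhibition. Compound 2 has the highest number of the three, clearly above both others. Compound 4 `O=C(CN1CCN(c2nnc(Cc3ccccc3)c3ccccc23)CC1)Nc1ccc(Br)cc1` keeps the rest of compound 2 and changes one group: 4-bromophenyl in place of 2,6-difluorophenyl on an amide-type nitrogen. Going by the values given here, one measured step bears on this, also a change on an amide-type nitrogen: a 5.8-fold lower number from compound 1 to compound 3 (0.76 log units; beyond the scatter). That single modest step, made on another parent, is thin support. A step of similar or smaller size towards a lower number is still expected, as compound 2 already sits at the top of the range. The expected step is a 2.8-fold lower number from compound 2 to compound 4 (0.45 log units; beyond the scatter). Compound 4 is estimated at 30000 nM, with an expected range of 8000 nM to 100000 nM.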

Compound 4, half-maximal inhibitory concentration: 2000 nM
Compound 4: the middle estimate sits 15-fold (1.18 log units) above what was measured; the measured number lies below the stated range.
By their numbers in this assay, from the lowest: compound 4; then compound 3; then compound 1; then compound 2.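

Going by these compounds alone, the aryl group on the amide-type nitrogen proves a far stronger lever in this assay than the earlier compounds showed: the change gives a 42-fold lower number from compound 2 to compound 4 (1.63 log units; beyond the scatter), a large step against the modest 5.8-fold lower number from compound 1 to compound 3 (0.76 log units; beyond the scatter) on another parent. It also shows that this place can matter on the parent of compound 2, not only on that of compound 1. Nothing measured here accounts for the size of this step.

Since the fluorine atoms leave as bromine enters, their separate shares remain unresolved. On these data alone, whether plain phenyl or 4-chlorophenyl on that nitrogen would behave like the 4-bromophenyl of compound 4 stays open.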